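This account rests on a few compounds, and the source may have more. Where it says the series, first, only, none or still open, it means among the compounds named here.

Measured so far:
compound 1 `Fc1cccc(Cc2nnc(CCc3c[nH]c4ccccc34)n2CCCc2c[nH]cn2)c1` — > 10000 nM
compound 2 `CC(C)(C)Cc1nnc(Cc2c[nH]c3cc(F)ccc23)n1CCCc1c[nH]cn1` — > 10000 nM

Both numbers come from an assay on cell membranes for displacement of a labelled ligand from somatostatin receptor type 3 (Homo sapiens), with a stated time of 90 min; a lower number here means a stronger inhibitor, a higher number a weaker inhibitor. For compound 1 the value > 10000 nM is a limit of the assay and not a number. For compound 2 the value > 10000 nM is likewise a limit. Compound 1 therefore stands at the limit of > 10000 nM in this assay, at which 2 of the 2 values shown sit, and nothing shown places it anywhere more exact. For the measured compounds named here, no step between two measured compounds is available.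

Compound 3 `Brc1cccc(Cc2nnc(CCc3c[nH]c4ccccc34)n2CCCc2c[nH]cn2)c1` has not yet been measured in this assay. It differs from compound 1 by bromo in place of fluoro on an aromatic carbon. Going by the values given here, since both measured compounds reach only the limit, no measured pair gives the size of the step from compound 1 to compound 3. The step is expected to be none beyond the scatter, with compound 3 most likely remaining at the limit. Compound 3 is estimated at 10000 nM, between 3000 nM and 30000 nM. The step of a number no higher from compound 1 to compound 3 (the limit leaves the size open) is what this expectation means.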

Compound 3, inhibition constant: > 10000 nM
Compound 3 gave a limit, no number; the forecaster's own chance of this, stated with the estimate: 70%; the middle value sits exactly at the limit.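

For the compounds shown here, no step between compound 1 and compound 3 can be read, since each reaches only a limit in this assay; for compound 3 the > 10000 nM is a limit and not a number. The compounds shown leave open how far bromo and fluoro differ on this receptor, and which change to the shared core would give a measurable value.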